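Ethyl for methyl on the amine of compound 2

The source may hold more compounds than are shown below. What is called first, only, known or untested is meant among the compounds shown, and "the series" means these compounds.

Measured compounds in a functional assay on CCRF-CEM cells (Homo sapiens) for cytotoxicity, read by resazurin assay, with a stated time of 48 h; a lower number here means a stronger inhibitor, a higher number a weaker inhibitor:
compound 1 `CCN/C(SC)=C(/C#N)C(=O)Nc1ccc(OCC)cc1` — 9890 nM
compound 2 `CCOc1ccc(-n2nnc3n[nH]c(NC)c3c2=O)cc1` — 12400 nM
compound 3 `CCOc1ccc(NC(=O)c2c(N)n[nH]c2Nc2ccccc2)cc1` — 4470 nM

Compound 2 holds the largest of the three numbers in this assay. Compound 1 sits within the scatter of it, so the two cannot be ordered on these data. Compound 3 lies beyond the scatter below compound 2, giving the only separation that counts among the measured set. Among the compounds with values here, none of the three pairs differs in a single place, so no step between measured compounds can be read off.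

Compound 4 `CCNc1[nH]nc2nnn(-c3ccc(OCC)cc3)c(=O)c12` has not yet been measured. It differs from compound 2 by methyl in place of hydrogen on a saturated chain carbon bound to a nitrogen on an aromatic ring, so the methylamino group on the core of compound 2 becomes ethylamino. Within the data shown here, nothing among the measured compounds speaks to the size of such a change, and the added group is small. The expectation is therefore a step from compound 2 to compound 4 of no more than the scatter, with no preferred direction, namely a 1.1-fold lower number from compound 2 to compound 4 (0.05 log units; within the scatter). On that basis compound 4 is estimated at 11000 nM in this assay, with a range from 4000 nM to 30000 nM.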

Compound 4, half-maximal inhibitory concentration: 15200 nM
The estimate for compound 4 lay 1.4-fold (0.14 log units) below the measured number; low and high end bracket the measured number.
By their numbers in this assay, from the lowest: compound 3; then compounds 1, 2 and 4 (each within the scatter of the next).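

In this assay, within the data shown here, the step of a 1.2-fold higher number from compound 2 to compound 4 (0.09 log units; within the scatter) is the first single-place comparison: methyl in place of hydrogen on a saturated chain carbon bound to a nitrogen on an aromatic ring, which turns methylamino into ethylamino on the shared core. Among these compounds, compound 2 and compound 4 cannot be ordered on this step, so at this position one added carbon leaves no separation that counts in this read-out, something the earlier compounds, none of which differed in a single place, could not show. No measurement on hand accounts for this outcome, and a single step of this size gives no trend along the chain.

As far as these compounds go, whether a longer chain such as propyl or butyl, a branched group such as isopropyl, or a ring such as cyclopropyl on this nitrogen would give a step beyond the scatter remains open. Equally open, from the compounds shown here alone, are the unsubstituted amine and a chain ending in a hydroxyl group or a carboxylic acid, which would show whether this position responds to anything other than a small alkyl group.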